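A few compounds are considered here, and "the series" means these few. Any claim that something is new, unique, unknown or untested is made for them only; others in the source may bear on it.

Measured in the series so far:
- compound 1 `COc1ccc(/C(=N/O)c2cccc3ccccc23)c(OC)c1OC`: 2500 nM
- compound 2 `COc1ccc(C(c2ccccc2O)c2cccc3ccccc23)c(OC)c1OC`: 17700 nM
- compound 3 `COc1ccc(/C(=C/c2ccc(F)cc2)c2cccc3ccccc23)c(OC)c1OC`: > 20000 nM

In a functional assay on MDA-MB-231 cells (Homo sapiens) for inhibition, read by sulforhodamine B assay, with a stated time of 48 h (on this read-out lower numbers stand for stronger inhibition and higher numbers for weaker inhibition), compound 1 gives 2500 nM, the lowest of the two numbers; the nearest, compound 2 at 17700 nM, sits a gap beyond the usual scatter higher. For compound 3 the read-out is only a limit of the assay, namely (the limit of > 20000 nM in this assay, at which 1 of the 3 values shown sits). Among the measured compounds shown here, no pair of measured compounds differs in a single place, so no measured step is available.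

Compound 4 `COc1ccc(/C(=N/OC(C)=O)c2cccc3ccccc23)c(OC)c1OC` differs from compound 1 by acetyl in place of hydrogen on an oxygen. For the measured compounds named here, no measured step speaks to this change, so a step of compound 4 relative to compound 1 in this assay is expected to stay within or close to the scatter, estimated as a 1.3-fold higher number from compound 1 to compound 4 (0.11 log units; within the scatter). Compound 4 is therefore estimated at 3200 nM, in the range 1000 nM to 10000 nM.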

Compound 4, half-maximal inhibitory concentration: 17000 nM
For compound 4 the middle estimate is 5.3-fold (0.73 log units) below the measured one, and the stated range ends below it.
By their numbers in this assay, from the lowest: compound 1; then compounds 4 and 2 (each within the scatter of the next). At a limit, above all of these: compound 3.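

In this assay, among the compounds shown here, hydroxy to acetoxy gives a 6.8-fold higher number from compound 1 to compound 4 (0.83 log units; beyond the scatter) and is the first measured single-place step. This oxygen on the double-bonded nitrogen therefore does not take an acetyl in place of its hydrogen without a loss of inhibition beyond the scatter. Nothing shown gives a cause for this step.

As far as these compounds go, whether the loss follows from removing the hydrogen or from the acetyl itself stays open; a methyl ether or a longer acyl chain such as propionyl on this oxygen would separate the two.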